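The source may report more compounds than this note shows. Statements on the series, on what has been measured and on what is new or still open speak of the compounds shown alone.

Measured in a functional assay (trachea) with Cavia porcellus as the target; a lower number here means a stronger inhibitor, a higher number a weaker inhibitor:
- compound 1 `CC(C)n1nc(-c2cccnc2)c2ccccc2c1=O`: 3090 nM
- compound 2 `O=c1c2ccccc2c(-c2cccnc2)nn1CCCCSc1ncccn1`: 6170 nM

Compound 2, at 6170 nM, lies within the scatter of compound 1, at 3090 nM, so the two cannot be separated in this assay. Next in the series is compound 3 `O=C(O)CCCn1nc(-c2cccnc2)c2ccccc2c1=O`, not yet measured. It carries carboxy in place of ((pyrimidin-2-yl)sulfanyl)methyl on a saturated chain carbon, three bonds along the chain from an aromatic nitrogen. For the measured compounds named here, no measured compound carries carboxy, and no measured step covers this change, so the expectation is tentative. A moderate move towards weaker inhibition is expected, and the range leaves room for no change beyond the scatter. The expected size is a 1.8-fold higher number from compound 2 to compound 3 (0.25 log units; within the scatter). For compound 3 the estimated value is 11000 nM, with an expected range of 3000 nM to 40000 nM.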

Compound 3, half-maximal inhibitory concentration: > 100000 nM
Compound 3: a limit, no number; the forecaster's own chance of this, stated with the estimate: 15%; middle value at least 9.0-fold (0.95 log units) away from the limit.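

In this assay compound 3 gives > 100000 nM, a limit of the assay and not a number: the limit of > 100000 nM in this assay, at which 1 of the 3 values shown sits.

Compound 1 and compound 2 lie within the scatter of each other, so isopropyl and the chain ending in (pyrimidin-2-yl)sulfanyl could not be separated on the aromatic nitrogen. This position is nevertheless not indifferent to every group: carboxy in place of ((pyrimidin-2-yl)sulfanyl)methyl gives an at least 16-fold higher number from compound 2 to compound 3 (1.20 log units; beyond the scatter), and 3-carboxypropyl in place of isopropyl gives an at least 32-fold higher number from compound 1 to compound 3 (1.51 log units; beyond the scatter).

The compounds shown do not tell whether the loss follows from the entering carboxy or from the leaving pyrimidine ring, since the step changes both at once. A methyl ester, a primary amide or an amine at the chain end would separate these two readings.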